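This account rests on a few compounds, and the source may have more. Where it says the series, first, only, none or still open, it means among the compounds named here.

Measured compounds:
compound 1 `CC(C)N1CCN(Cc2csc(N)c2C(=O)c2ccc(Cl)cc2)CC1` with 0%
compound 2 `Nc1scc(CN2CCN(c3ccc(Cl)cc3Cl)CC2)c1C(=O)c1ccc(Cl)cc1` with 0%

In an assay on CHO cells for displacement of a labelled ligand from adenosine receptor A3 (Homo sapiens), read by scintillation counting, with a stated time of 120 min, tested at 10 uM (a higher number here means more inhibition at the concentration tested (going by the name of the read-out), a lower number less inhibition), compound 1 gives 0%, and compound 2 gives 0%. Among the compounds with values here, compound 1 therefore stands level with compound 2, its only measured neighbour, with the step of no change at the digits printed from compound 1 to compound 2 (within the scatter) falling within the scatter when 2,4-dichlorophenyl replaces isopropyl on the amine nitrogen in the ring.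

Compound 3 `Nc1scc(CN2CCN(c3ccncc3)CC2)c1C(=O)c1ccc(Cl)cc1` differs from compound 1 by pyridin-4-yl in place of isopropyl on an amine nitrogen in a ring. Within the data shown here, the one measured step at this same position, from an alkyl group to an aryl group, gave no change in this assay. Among the measured compounds shown here, no measured step here moves the read-out beyond the scatter, and both measured compounds sit at the floor of the read-out. For compound 3 the step of a number 2 percentage points higher from compound 1 to compound 3 (within the scatter) is therefore expected to stay within the scatter. For compound 3 the estimated value is 2%, with a range from -5% to 15%.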

Compound 3, a percentage reported as inhibition, at one concentration (the size of the read-out at that concentration, not a potency): 2%
Beside the measured number, compound 3's estimate shows no gap at the digits printed, and the stated range covers the measured number.
By their numbers in this assay, from the lowest: compounds 1, 2 and 3 (each within the scatter of the next).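

In this assay, pyridin-4-yl on the amine nitrogen in a ring gives a number 2 percentage points higher from compound 1 to compound 3 (within the scatter), and set against 2,4-dichlorophenyl at the same place it gives a number 2 percentage points higher from compound 2 to compound 3 (within the scatter). This position has now carried an alkyl group and two different aromatic rings, one of them with a hetero atom and a hydrogen-bond acceptor, and all three compounds stay within the scatter of one another, so neither that hetero atom nor that acceptor brings a readable change at the concentration tested. No supporting evidence is available to explain this result.

With all three compounds at or near the floor of the read-out, this assay cannot separate them. From the compounds shown here alone, it remains open whether a benzyl group, a carboxylic acid or a longer chain bearing an amine on this nitrogen would lift the read-out, or whether a change elsewhere on the shared core would.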